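Branched alkyl swap on a cyanoguanidine blood-pressure lowering series

This account rests on a few compounds, and the source may have more. Where it says the series, first, only, none or still open, it means among the compounds named here.

Measured so far:
- compound 1, `N#CN/C(=N\CC1CCCO1)Nc1cccnc1`, 50 mg/kg
- compound 2, `CCC(CC)/N=C(\NC#N)Nc1ccncc1`, 2.5 mg/kg

Of the compounds shown here, two have been tested in a functional assay on the whole organism (blood, strain Wistar-Okamoto) with Rattus norvegicus as the target, with a stated time of 5 days; on this read-out lower numbers stand for an effect already at smaller amounts and higher numbers for an effect only at larger amounts of compound. Compound 1 `N#CN/C(=N\CC1CCCO1)Nc1cccnc1` needs 50 mg/kg, whereas compound 2 `CCC(CC)/N=C(\NC#N)Nc1ccncc1` is effective at 2.5 mg/kg. Compound 2 thus stands at the lowest number of the two, and its gap to compound 1 lies well beyond the scatter; the two differ in more than one place, so no single change can be read from that gap.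

Compound 3 `CC(C)(C)/N=C(\NC#N)Nc1ccncc1` is the next candidate. It differs from compound 2 in one place only: tert-butyl in place of pentan-3-yl on a double-bonded nitrogen. Within the data shown here, both groups are short branched chains without heteroatoms, rings or charge, and no pair of measured compounds shows what such a change does here. A step within the scatter is therefore expected, with no clear direction, so the estimate for compound 3 is 3 mg/kg, in the range 1 mg/kg to 10 mg/kg, which means an expected step of a 1.2-fold higher number from compound 2 to compound 3 (0.08 log units; within the scatter) in this assay.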

Compound 3, minimum effective dose: 2.5 mg/kg
For compound 3 the middle estimate is 1.2-fold (0.08 log units) above the measured one, and the stated range covers the measured number.
By their numbers in this assay, from the lowest: compounds 2 and 3 (each within the scatter of the next); then compound 1.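

In this assay, among these compounds, putting tert-butyl in place of pentan-3-yl on a double-bonded nitrogen gives no change at the digits printed from compound 2 to compound 3 (within the scatter), and this is the first comparison that isolates a change in one place. It shows that this position accepts either of these two branched chains, one of 5 heavy atoms and the other of 4, with no step beyond the scatter. No measurement offered here bears on why the two chains match.

The two chains are alike in being branched and all carbon, so they leave open what a straight pentyl chain, a small methyl group or a cyclohexyl group would do at this position. From the compounds shown here alone, it also remains open whether a chain carrying a hydroxyl group or an amine would keep the number of compound 2 and compound 3.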